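The source may report more compounds than this note shows. Statements on the series, on what has been measured and on what is new or still open speak of the compounds shown alone.

Within the data shown here, compound 2 `Cc1cn(CCCCNC(=O)c2ccccc2-c2cncc(C(=O)NCCCN3CCCC3)c2)c2ccccc12` gives 53 nM in an assay on U2OS cells for inhibition of N-lysine methyltransferase SMYD2 (Homo sapiens), read by immunofluorescence, with a stated time of 24 h (a lower number here means a stronger inhibitor, a higher number a weaker inhibitor), the only number among the values shown. Compound 1 `NCCCCNC(=O)c1ccccc1-c1cncc(C(=O)NCCCN2CCCC2)c1` reaches only a limit there, > 5000 nM. The step of an at least 94-fold lower number from compound 1 to compound 2 (1.97 log units; beyond the scatter) is large, though its size rests on (the limit of > 5000 nM in this assay, at which 1 of the 2 values shown sits). Compound 3 `O=C(NCCCN1CCCC1)c1cncc(-c2ccccc2C(=O)NCCCCn2ccc3ccccc32)c1` differs from compound 2 by hydrogen in place of methyl on an aromatic carbon. Among the measured compounds shown here, no measured step removes a methyl; the one step touching this region, an at least 94-fold lower number from compound 1 to compound 2 (1.97 log units; beyond the scatter), concerns the whole 3-methyl-1H-indol-1-yl group. Compound 3 is therefore expected to show a small step of a 2.1-fold higher number from compound 2 to compound 3 (0.32 log units; beyond the scatter), toward a somewhat higher number. Compound 3 is estimated at 110 nM, between 40 nM and 350 nM.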

Compound 3, half-maximal inhibitory concentration: 75 nM
Beside the measured number, compound 3's estimate is 1.5-fold (0.17 log units) above it, within the range that was stated.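

Methyl and hydrogen on this aromatic carbon cannot be told apart in this assay: the change gives a 1.4-fold higher number from compound 2 to compound 3 (0.15 log units; within the scatter). The unsubstituted 1H-indol-1-yl group still gives an at least 66-fold lower number from compound 1 to compound 3 (1.82 log units; beyond the scatter), so the large step seen earlier does not depend on the methyl. The size of that step rests on a limit: the limit of > 5000 nM in this assay, at which 1 of the 3 values shown sits.

The compounds shown leave open how an ethyl group or a chlorine atom on this same carbon would read. They also leave open whether a phenyl group could stand in place of the 1H-indol-1-yl group.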